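Replacing 4-methoxyphenyl with 3-methylphenyl on the ring nitrogen

A few compounds are considered here, and "the series" means these few. Any claim that something is new, unique, unknown or untested is made for them only; others in the source may bear on it.

Of the compounds shown here, three sharing one core have been tested in a functional assay, with a stated time of 20 min, tested at 2 mg/mL; on this read-out lower numbers stand for a weaker effect and higher numbers for a stronger effect at the one concentration tested. Compound 1 `CC(C)[C@@H]1CC[C@@H](C)C[C@@]12N(C)C(=O)[C@@H]1[C@H]3C(=O)NC(=O)[C@H]3ON12` gives 58.7%. Compound 2 `CC(C)[C@@H]1CC[C@@H](C)C[C@@]12N(C)C(=O)[C@@H]1[C@H]3C(=O)N(c4ccc(Cl)cc4)C(=O)[C@H]3ON12` gives 48.2%, and compound 3 `COc1ccc(N2C(=O)[C@H]3[C@H](ON4[C@@H]3C(=O)N(C)[C@@]43C[C@H](C)CC[C@H]3C(C)C)C2=O)cc1` gives 61.7%, the highest of the three numbers; compound 1 lies within the scatter of it, while the step of a number 13.5 percentage points higher from compound 2 to compound 3 (beyond the scatter) lies beyond the scatter. Compound 4 `Cc1cccc(N2C(=O)[C@H]3[C@H](ON4[C@@H]3C(=O)N(C)[C@@]43C[C@H](C)CC[C@H]3C(C)C)C2=O)c1` differs from compound 3 in one place: 3-methylphenyl in place of 4-methoxyphenyl on an amide-type nitrogen in a ring. Going by the values given here, no measured step swaps one substituted phenyl for another of this kind. Among the compounds with values here, the only step between two phenyl groups, a number 13.5 percentage points higher from compound 2 to compound 3 (beyond the scatter), was modest, and the two steps from the bare amide nitrogen, a number 10.5 percentage points lower from compound 1 to compound 2 (beyond the scatter) and a number 3 percentage points higher from compound 1 to compound 3 (within the scatter), were also modest and ran in opposite directions. Compound 4 is therefore expected to show a step of a number 6.7 percentage points lower from compound 3 to compound 4 (within the scatter), with an estimated value of 55% and a range from 40% to 68%.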

Compound 4, a percentage reported as activity, at one concentration (the size of the read-out at that concentration, not a potency): 49.9%
Compound 4: the middle estimate sits 5.1 percentage points above what was measured, and the stated range covers the measured number.
By their numbers in this assay, from the lowest: compounds 2, 4, 1 and 3 (each within the scatter of the next, the first and the last beyond it).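

In this assay, the ring nitrogen proves sensitive to a swap of one substituted phenyl for another (a number 11.8 percentage points lower from compound 3 to compound 4 (beyond the scatter)). Compound 4 cannot be told apart from the 4-chlorophenyl compound (a number 1.7 percentage points higher from compound 2 to compound 4 (within the scatter)) or from the compound with the bare amide hydrogen (a number 8.8 percentage points lower from compound 1 to compound 4 (within the scatter)). Among the three phenyl groups, only 4-methoxyphenyl stands clear of the other two.

On these data alone, whether an amine or a carboxylic acid on the phenyl ring, or a longer chain in place of it, would raise the number remains open. Why 4-methoxyphenyl and 3-methylphenyl differ also remains open, with no measurement here that bears on it.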